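The source may report more compounds than this note shows. Statements on the series, on what has been measured and on what is new or still open speak of the compounds shown alone.

Measured compounds:
- compound 1, `CCc1cccc(-n2cc(COc3cccc(NC(=O)Nc4ccc(Cl)c(C(F)(F)F)c4)c3)nn2)c1` — 37900 nM
- compound 2, `CC(C)c1ccccc1-n1cc(COc2cccc(NC(=O)Nc3ccc(Cl)c(C(F)(F)F)c3)c2)nn1` — 1900 nM
- compound 3, `O=C(Nc1cccc(OCc2cn(-c3ccccc3Cl)nn2)c1)Nc1ccc(Cl)c(C(F)(F)F)c1` — 1960 nM

All three were tested in a functional assay on HepG2 cells (Homo sapiens) for inhibition, read by MTT assay, with a stated time of 72 h; a higher number here means a weaker inhibitor, a lower number a stronger inhibitor. Compound 2 gives the lowest of the three numbers, but compound 3 sits within the scatter of it, so the two cannot be ranked against each other; compound 1 lies far apart, the step being a 20-fold lower number from compound 1 to compound 2 (1.30 log units; beyond the scatter). The change to the unmeasured compound 4, `O=C(Nc1cccc(OCc2cn(-c3cccc(Br)c3)nn2)c1)Nc1ccc(Cl)c(C(F)(F)F)c1`, is 3-bromophenyl in place of 2-isopropylphenyl on an aromatic nitrogen. Within the data shown here, two measured steps bear on it. Both replace the 3-ethylphenyl of compound 1: a 20-fold lower number from compound 1 to compound 2 (1.30 log units; beyond the scatter) and a 19-fold lower number from compound 1 to compound 3 (1.29 log units; beyond the scatter). In contrast, a 1.0-fold higher number from compound 2 to compound 3 (0.01 log units; within the scatter) shows that swapping between 2-isopropylphenyl and 2-chlorophenyl changes little. Compound 4 carries a 3-bromophenyl, which resembles the 3-ethylphenyl of compound 1 more than the 2-substituted rings of compounds 2 and 3, so a large step toward a higher number is expected, though bromine is not ethyl and the return need not be complete. Compound 4 is therefore expected to give about 15000 nM, within 4000 nM to 45000 nM. This estimate means an expected step of a 7.9-fold higher number from compound 2 to compound 4 (0.90 log units; beyond the scatter).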

Compound 4, half-maximal inhibitory concentration: 1040 nM
Beside the measured number, compound 4's estimate is 14-fold (1.16 log units) above it; the measured number lies below the stated range.
By their numbers in this assay, from the lowest: compounds 4, 2 and 3 (each within the scatter of the next); then compound 1.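

Compound 4 shows that a 3-bromophenyl on this aromatic nitrogen cannot be told apart from the 2-isopropylphenyl or 2-chlorophenyl rings in this assay, with a 1.8-fold lower number from compound 2 to compound 4 (0.26 log units; within the scatter) and a 1.9-fold lower number from compound 3 to compound 4 (0.28 log units; within the scatter). The high number of compound 1 therefore does not extend to every ring with a group at that carbon: bromo in place of ethyl alone gives a 36-fold lower number from compound 1 to compound 4 (1.56 log units; beyond the scatter), so the identity of the group there matters greatly. No measurement here explains why bromo and ethyl part so widely at this place.

The compounds shown leave open how a plain phenyl, a 3-methoxyphenyl or a 3-aminophenyl would compare on this nitrogen. They also leave open whether a 2-bromophenyl would match the 3-bromophenyl of compound 4.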